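Acrylamide tail amines on the shared core

The source may hold more compounds than are shown below. What is called first, only, known or untested is meant among the compounds shown, and "the series" means these compounds.

Three analogues share one core, differing only in the acyl group on the anilide nitrogen. Compound 1 `CC(C)=CC(=O)Nc1cc2c(N3CCCc4ccccc43)ncnc2cc1O[C@@H]1CCOC1` gives 9020 nM in a functional assay on PC-3 cells (Homo sapiens) for antiproliferative activity, read by MTT assay, with a stated time of 72 h; on this read-out higher numbers stand for weaker inhibition and lower numbers for stronger inhibition; compound 2 `CC/C=C/C(=O)Nc1cc2c(N3CCCc4ccccc43)ncnc2cc1O[C@@H]1CCOC1` gives 14300 nM; compound 3 `CN(C)C/C=C/C(=O)Nc1cc2c(N3CCCc4ccccc43)ncnc2cc1O[C@@H]1CCOC1` gives 4170 nM. Compound 3 stands lowest of the three numbers: a 2.2-fold lower number from compound 1 to compound 3 (0.34 log units; beyond the scatter) and a 3.4-fold lower number from compound 2 to compound 3 (0.54 log units; beyond the scatter), while a 1.6-fold higher number from compound 1 to compound 2 (0.20 log units; within the scatter). Both steps into compound 3 bring in a basic amine where none was before, and both land beyond the scatter in the direction of stronger inhibition.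

Compound 4 `CCN(CC)C/C=C/C(=O)Nc1cc2c(N3CCCc4ccccc43)ncnc2cc1O[C@@H]1CCOC1` keeps that amine and only changes its size: diethylamino in place of dimethylamino on a saturated chain carbon bound to a double-bonded chain carbon. For the measured compounds named here, no measured pair varies the alkyl groups on the amine nitrogen itself, so the two steps into compound 3 speak only to the presence of the amine, not to this change. On that basis the expectation for compound 4 in this assay is a step of about a 1.0-fold lower number from compound 3 to compound 4 (0.02 log units; within the scatter) relative to compound 3, that is, no change beyond the scatter, with the direction left open.

Compound 4 is accordingly estimated at 4000 nM in this assay, with a range from 1800 nM to 9000 nM.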

Compound 4, half-maximal inhibitory concentration: 4270 nM
The estimate for compound 4 lay 1.1-fold (0.03 log units) below the measured number; the range from low to high includes it.
By their numbers in this assay, from the lowest: compounds 3 and 4 (each within the scatter of the next); then compounds 1 and 2 (each within the scatter of the next).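

Notes on the tail amine: in this assay, dimethylamino and diethylamino on a saturated chain carbon bound to a double-bonded chain carbon read alike, with a 1.0-fold higher number from compound 3 to compound 4 (0.01 log units; within the scatter), so going from 3 to 5 heavy atoms in this group does not separate the two compounds. The step away from the amine-free tails holds with diethylamino as well: a 3.3-fold lower number from compound 2 to compound 4 (0.52 log units; beyond the scatter) and a 2.1-fold lower number from compound 1 to compound 4 (0.32 log units; beyond the scatter) both lie beyond the scatter, as the steps into compound 3 do. Among the four compounds shown, then, the pair carrying a tail amine gives the lower numbers and the pair without one the higher, with no compound going against this, and the size of the alkyl groups on that nitrogen has so far made no mark on the read-out.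

Still open, as far as these compounds go, is whether the same holds for a ring amine such as pyrrolidine, piperidine or morpholine at this place, for an amine with a single alkyl group, or for a longer chain leading to the amine. Nothing available here speaks to why the tail amine compounds give the lower numbers.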